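Working notes on cytotoxicity in an amidoxime sulfone series

A few compounds are considered here, and "the series" means these few. Any claim that something is new, unique, unknown or untested is made for them only; others in the source may bear on it.

Three compounds of this series carry a value in an ADME assay on HepG2 cells (Homo sapiens) for cytotoxicity, read by MTT assay, with a stated time of 72 h; a lower number here means that less compound is tolerated, a higher number that more compound is tolerated. Compound 1 `CC1(c2ccc(-c3ccco3)cc2)CC(S(=O)(=O)c2ccc(F)cc2)=C(c2ccc(/C(N)=N\O)cc2)O1` gives 7010 nM. Among the compounds with values here, compound 2 `CC1(c2ccc(-c3cccc(/C(N)=N\O)c3)cc2)CC(S(=O)(=O)c2ccc(F)cc2)=C(c2ccc(/C(N)=N\O)cc2)O1` gives 19000 nM; between these two, a 2.7-fold higher number from compound 1 to compound 2 (0.43 log units; beyond the scatter) is the only single-point step with a known outcome. Compound 3 `CC1(Cc2ccccc2)CC(S(=O)(=O)c2ccccc2F)=C(c2ccc(/C(N)=N\O)cc2)O1` gives 61700 nM, the highest of the three numbers; its gap to compound 2 and its larger gap to compound 1 both lie beyond the scatter, so compound 3 is the best tolerated of the measured set.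

Compound 4 `CC1(Cc2ccccc2)CC(S(=O)(=O)c2cccc(F)c2)=C(c2ccc(/C(N)=N\O)cc2)O1` has not yet been measured in this assay. It differs from compound 3 in one place: 3-fluorophenyl in place of 2-fluorophenyl on a sulfonyl sulfur. Within the data shown here, the measured step concerns a different part of the molecule, and no measured pair isolates the fluorophenyl on the sulfonyl sulfur; compound 3 differs from compound 1 and compound 2 in more than one place, so its larger number cannot be tied to any single group. The data therefore give no direction for this change. The expected step of a 1.0-fold lower number from compound 3 to compound 4 (0.01 log units; within the scatter) for compound 4 is none beyond the scatter. Compound 4 is accordingly estimated at 60000 nM, with a range from 25000 nM to 140000 nM.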

Compound 4, half-maximal cytotoxic concentration: 59600 nM
Compound 4: the middle estimate sits 1.0-fold (0.00 log units) above what was measured; low and high end bracket the measured number.
By their numbers in this assay, from the lowest: compound 1; then compound 2; then compounds 4 and 3 (each within the scatter of the next).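

In this assay, within the data shown here, 3-fluorophenyl in place of 2-fluorophenyl on a sulfonyl sulfur gives a 1.0-fold lower number from compound 3 to compound 4 (0.02 log units; within the scatter), and this is the first measured pair that isolates the fluorophenyl on the sulfonyl sulfur. On the core shared by compound 3 and compound 4, this exchange therefore does not separate the two compounds, so the reading holds for this one exchange on this one core and says nothing yet about other groups at the same place. No evidence is at hand that accounts for the two fluorophenyl groups reading alike.

The compounds shown leave open whether a group other than fluorophenyl on the sulfonyl sulfur, such as a chlorophenyl, a methoxyphenyl, a pyridyl ring or a plain alkyl chain, would stay level with compound 3 or move the number beyond the scatter. Also open, from the compounds shown here alone, is whether the same exchange would read alike on the core of compound 1, which carries different groups elsewhere, so that the present result cannot yet be extended to the rest of the series.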